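Cytotoxicity notes: fluoro to chloro on the anilide

The source may report more compounds than this note shows. Statements on the series, on what has been measured and on what is new or still open speak of the compounds shown alone.

Compound 2 `CCCCc1nc(Cl)c(C2NC(=O)NC(C)=C2C(=O)Nc2ccc(F)cc2)[nH]1`: > 10 ug/mL
Compound 1 `CCCCc1nc(Cl)c(C2NC(=O)NC(C)=C2C(=O)Nc2cccc(F)c2)[nH]1`: "not determined" (no result reported)
Compound 3 `CCCCc1nc(Cl)c(C2NC(=O)NC(C)=C2C(=O)Nc2cccc(Cl)c2)[nH]1`: "not determined" (no result reported)

In an ADME assay on Vero cells (Chlorocebus sabaeus) for cytotoxicity, read by MTT assay, with a stated time of 72 h (a lower number here means a stronger inhibitor, a higher number a weaker inhibitor), compound 2 gives only a limit, > 10 ug/mL. For compound 1 this assay holds "not determined" (no result reported). For compound 3 this assay holds "not determined" (no result reported). Compound 2 therefore stands at the limit of > 10 ug/mL in this assay, at which 1 of the 3 values shown sits, with no single number anywhere in the series to place it against.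

Compound 4 `CCCCc1nc(Cl)c(C2NC(=O)NC(C)=C2C(=O)Nc2ccc(Cl)cc2)[nH]1` differs from compound 2 by chloro in place of fluoro on an aromatic carbon. Among the compounds with values here, no step between measured compounds is known, so the size of this change in this assay cannot be read from the series. The expected step that the limit leaves unreadable from compound 2 to compound 4 is essentially none beyond the scatter. Compound 4 is therefore estimated at 15 ug/mL, with a range from 5 ug/mL to 50 ug/mL, most likely again reported as a limit.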

Compound 4, half-maximal inhibitory concentration: 9.4 ug/mL
Compound 4: middle estimate off by 1.6-fold (0.20 log units), on the high side, and the stated range covers the measured number.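

In this assay, within the data shown here, compound 4 gives 9.4 ug/mL, the only single number, with chloro on an aromatic carbon para to a large group. Compound 2 is held only as a limit: the limit of > 10 ug/mL in this assay, at which 1 of the 4 values shown sits.

Going by these compounds, the change from 4-fluorophenyl to 4-chlorophenyl therefore reads only as a floor, an at least 1.0-fold lower number from compound 2 to compound 4 (0.02 log units; that floor lies within the scatter), and its true size remains unknown.

Steps to compound 1 and compound 3 cannot be read, so any effect of where the halogen sits on that ring stays open. Also open, on these data alone, is how an amine or a methoxy group at this place would read in this assay.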